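Aryl hydrazone series: corticotropin-releasing factor receptor 1 binding

A few compounds are considered here, and "the series" means these few. Any claim that something is new, unique, unknown or untested is made for them only; others in the source may bear on it.

Measured compounds:
compound 1 `CC(=O)/C(=N\c1cccc(Cl)c1)NNc1ccc(C)cc1` — 2290 nM
compound 2 `CC(=O)/C(=N\c1ccccc1)NNc1ccccc1C` — 526 nM
compound 3 `CC(=O)/C(=N\c1ccc(Cl)cc1)NNc1ccccc1C` — 1830 nM

In an assay on isolated protein for binding affinity to corticotropin-releasing factor receptor 1 (Homo sapiens) (on this read-out higher numbers stand for weaker inhibition and lower numbers for stronger inhibition), compound 3 gives 1830 nM, the second highest of the three numbers; compound 1 lies within the scatter of it, and compound 2 stands apart with 526 nM. Compound 4 `CC(=O)/C(=N\c1cccc(C)c1)NNc1ccccc1C` differs from compound 3 by 3-methylphenyl in place of 4-chlorophenyl on a double-bonded nitrogen. Within the data shown here, the only step that bears on this is a 3.5-fold higher number from compound 2 to compound 3 (0.54 log units; beyond the scatter), where chloro entered the same ring; compound 4 removes that chloro again and brings in a methyl, for which no measured step exists. The removal is expected to undo most of that step, so compound 4 is expected to return toward compound 2, with a 2.6-fold lower number from compound 3 to compound 4 (0.42 log units; beyond the scatter). Compound 4 is estimated at 700 nM, range 300 nM to 1800 nM.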

Compound 4, inhibition constant: 526 nM
Compound 4: the middle estimate sits 1.3-fold (0.12 log units) above what was measured; the range from low to high includes it.
By their numbers in this assay, from the lowest: compounds 2 and 4 (each within the scatter of the next); then compounds 3 and 1 (each within the scatter of the next).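

In this assay, 3-methylphenyl in place of 4-chlorophenyl on the double-bonded nitrogen gives a 3.5-fold lower number from compound 3 to compound 4 (0.54 log units; beyond the scatter) and so matches in size, in the opposite direction, the earlier 3.5-fold higher number from compound 2 to compound 3 (0.54 log units; beyond the scatter) where chloro entered the same ring. Methyl in place of hydrogen gives no change at the digits printed from compound 2 to compound 4 (within the scatter) and so this ring accepts the methyl without a readable change in binding. Nothing available bears on the reason for either step.

The step to 3-methylphenyl changes both the group and its place on the ring, and the two contributions remain unseparated. On these data alone, whether 3-methoxyphenyl or 3-aminophenyl on the same nitrogen would behave like 3-methylphenyl remains open.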